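This account rests on a few compounds, and the source may have more. Where it says the series, first, only, none or still open, it means among the compounds named here.

In an in vivo ADME assay on the whole organism (strain Sprague-Dawley) for pharmacokinetics, with Rattus norvegicus as the target (on this read-out lower numbers stand for narrower distribution and higher numbers for wider distribution into tissues), compound 2 (`Cc1cc([C@@H]2C[C@H]2C(=O)O)ccc1-c1noc(-c2ccc(OC(C)C)c(C(F)(F)F)c2)n1`) gives 1.1 L/kg. Compound 3 (`Cc1cc([C@H]2C[C@H]2C(=O)O)ccc1-c1noc(-c2ccc(OC(C)C)c(C#N)c2)n1`) gives 0.7 L/kg, which lies within the scatter of compound 2. Compound 1 (`Cc1cc(CCC(=O)O)ccc1-c1noc(-c2ccc(OC(C)C)c(C#N)c2)n1`) gives 0.2 L/kg, which lies beyond the scatter of compound 2.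

The open question is compound 4 (`Cc1cc(CCC(=O)O)ccc1-c1noc(-c2ccc(OC(C)C)c(C(F)(F)F)c2)n1`), which keeps the trifluoromethyl group of compound 2 but has 2-carboxyethyl in place of 2-carboxycyclopropyl on an aromatic carbon.

Among the compounds with values here, one measured step bears on this change, and it runs in the opposite direction. It is a 3.5-fold higher number from compound 1 to compound 3 (0.54 log units; beyond the scatter), a modest step beyond the scatter that exchanges the same two groups at the same place, though with a nitrile rather than a trifluoromethyl group on the core. Within the data shown here, no measured pair tests the exchange with trifluoromethyl present, so its transfer remains an assumption.

Read in reverse, that step suggests a lower number in this assay, of about the same size. The expected change is a 3.1-fold lower number from compound 2 to compound 4 (0.50 log units; beyond the scatter). Compound 4 is estimated at 0.35 L/kg, with an expected range from 0.15 L/kg to 0.8 L/kg.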

Compound 4, volume of distribution at steady state: 1.1 L/kg
Compound 4: the middle estimate sits 3.1-fold (0.50 log units) below what was measured; the measured number lies above the stated range.
By their numbers in this assay, from the lowest: compound 1; then compounds 3, 2 and 4 (each within the scatter of the next).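

In this assay, 2-carboxyethyl in place of 2-carboxycyclopropyl on this aromatic carbon gives no change at the digits printed from compound 2 to compound 4 (within the scatter) when trifluoromethyl sits on the core, whereas with a nitrile on the core the reverse exchange gives a 3.5-fold higher number from compound 1 to compound 3 (0.54 log units; beyond the scatter) and so lies beyond the scatter. Within the data shown here, the effect of this exchange therefore differs between the two pairs, and the earlier compounds alone could not show this. With the 2-carboxyethyl chain held constant, trifluoromethyl in place of cyano gives a 5.5-fold higher number from compound 1 to compound 4 (0.74 log units; beyond the scatter) in the same read-out, so a change at this other place on the core can also move the number beyond the scatter, and the data shown offer no measurement that accounts for either step.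

The compounds shown leave open how much of the contrast between the two exchanges comes from the group on the core, since the 2-carboxycyclopropyl group is drawn with different stereocentres in compound 2 and compound 3. They also leave open whether the same pattern would hold with a chlorine atom or a methoxy group in place of trifluoromethyl, or with a longer chain carrying the carboxylic acid.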